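The source may report more compounds than this note shows. Statements on the series, on what has been measured and on what is new or still open speak of the compounds shown alone.

Measured in a functional assay on A549 cells (Homo sapiens) for antiproliferative activity, read by sulforhodamine B assay, with a stated time of 72 h; a lower number here means a stronger inhibitor, a higher number a weaker inhibitor:
compound 1 `CCCCS(=O)(=O)Nc1cc(-c2ccc3ncnc(NCCN(C)C)c3c2)cnc1OC`: 1320 nM
compound 2 `COc1ncc(-c2ccc3ncnc(NCCN(C)C)c3c2)cc1NS(C)(=O)=O`: 4120 nM

Compound 2 has the higher, weaker number of the pair. Compound 3 `COc1ncc(-c2ccc3ncnc(NCCN(C)C)c3c2)cc1NS(=O)(=O)c1ccc(F)cc1` has 4-fluorophenyl in place of methyl on a sulfonyl sulfur. Within the data shown here, the only measured step bearing on this is a 3.1-fold higher number from compound 1 to compound 2 (0.49 log units; beyond the scatter), which also changes the group on that sulfur. No ring on the sulfur has been measured, so the precedent is thin. A modest move toward a lower number in this assay is expected, stated as a 5.2-fold lower number from compound 2 to compound 3 (0.71 log units; beyond the scatter). The estimate for compound 3 is 800 nM, with an expected range of 150 nM to 3000 nM.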

Compound 3, half-maximal inhibitory concentration: 2420 nM
Compound 3: the middle estimate sits 3.0-fold (0.48 log units) below what was measured; measured number inside the range.
By their numbers in this assay, from the lowest: compounds 1, 3 and 2 (each within the scatter of the next, the first and the last beyond it).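

On a sulfonyl sulfur whose other neighbour is the sulfonamide nitrogen, an aromatic ring now reads against two chains in this assay: 4-fluorophenyl for methyl gives a 1.7-fold lower number from compound 2 to compound 3 (0.23 log units; within the scatter) and 4-fluorophenyl for butyl gives a 1.8-fold higher number from compound 1 to compound 3 (0.26 log units; within the scatter) with both steps inside the scatter. The ring thus does not separate from either chain, although methyl and butyl do separate from each other. No measured evidence accounts for this.

Still open, as far as these compounds go, is whether phenyl without fluorine, 4-methoxyphenyl or a chain longer than butyl would move beyond the scatter of compound 3. From the compounds shown here alone, a terminal amine on the sulfonyl chain also remains open.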